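Compound 3 and a new group on the thiocarbonyl carbon

The source may report more compounds than this note shows. Statements on the series, on what has been measured and on what is new or still open speak of the compounds shown alone.

Compound 1 `COc1ccc(CN(C(=O)CSC(=S)N2CCN(C(C)=O)CC2)c2cc(OC)c(OC)c(OC)c2)cc1` was tested in a functional assay on KYSE-450 cells (Homo sapiens) for inhibition, read by CCK-8 assay, with a stated time of 48 h (a higher number here means a weaker inhibitor, a lower number a stronger inhibitor), where compound 1 gives 370 nM. Among the two numbers known it stands as the higher one; its only neighbour is compound 2 `COc1ccc(CN(C(=O)CSC(=S)N2CCN(C(=O)OC(C)(C)C)CC2)c2cc(OC)c(OC)c(OC)c2)cc1`, which in this assay gives 250 nM. For the measured compounds named here, the one measured step, a 1.5-fold lower number from compound 1 to compound 2 (0.17 log units; within the scatter), concerns the group on a carbonyl carbon and lies within the scatter. Compound 3 `COc1ccc(CN(C(=O)CSC(=S)N2CCCc3cc(OC)ccc32)c2cc(OC)c(OC)c(OC)c2)cc1` differs from compound 1 at another place: 6-methoxy-1,2,3,4-tetrahydroquinolin-1-yl in place of 4-acetylpiperazin-1-yl on a thiocarbonyl carbon. Going by the values given here, no measured step bears directly on this exchange; the one step known concerns a different place and was small. The whole ring system on the thiocarbonyl carbon is exchanged. A change in this assay beyond the scatter cannot be excluded, but no direction can be read from the data. For compound 3 the step of a 1.2-fold lower number from compound 1 to compound 3 (0.09 log units; within the scatter) is therefore expected to stay small. Compound 3 is estimated at 300 nM, within 80 nM to 1200 nM.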

Compound 3, half-maximal inhibitory concentration: 5530 nM
Beside the measured number, compound 3's estimate is 18-fold (1.27 log units) below it; measured number above the stated range.
By their numbers in this assay, from the lowest: compounds 2 and 1 (each within the scatter of the next); then compound 3.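

The thiocarbonyl carbon turns out to be a place where this assay responds strongly: 6-methoxy-1,2,3,4-tetrahydroquinolin-1-yl in place of 4-acetylpiperazin-1-yl gives a 15-fold higher number from compound 1 to compound 3 (1.17 log units; beyond the scatter), whereas the earlier change on a carbonyl carbon, a 1.5-fold lower number from compound 1 to compound 2 (0.17 log units; within the scatter), did not move the number beyond the scatter. The exchange alters several features at once, since a ring with 2 hetero atoms leaves while a ring with 1 hetero atom and an aromatic ring of carbon only enter, so the weaker result cannot be assigned to any one of them. Nothing at hand explains the size of this step.

Going by these compounds, how a plain piperidin-1-yl or morpholin-4-yl group would fare on the thiocarbonyl carbon remains open. On these data alone, it is equally open whether the 1,2,3,4-tetrahydroquinolin-1-yl group without its methoxy would give a similar number.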